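This account rests on a few compounds, and the source may have more. Where it says the series, first, only, none or still open, it means among the compounds named here.

Measured compounds in a functional assay (cardiac atrium) for agonist activity, with Cavia porcellus as the target; a lower number here means that less compound is needed, a higher number that more compound is needed for the effect:
- compound 1 `CO/C(O)=C1\C(C)=NC(C)=C([N+](=O)[O-])C1c1ccncc1`: compound 1 gives 48500 nM
- compound 2 `CC1=NC(C)=C([N+](=O)[O-])C(c2ccncc2)/C1=C(\O)OC1CCCCC1`: compound 2 gives 4940 nM
- compound 3 `CC1=NC(C)=C([N+](=O)[O-])C(c2ccncc2)/C1=C(\O)OCC(C)C`: compound 3 gives 8510 nM

Compound 3 stands second highest of the three numbers in this assay. Its nearest neighbour is compound 2, separated by a gap within the scatter a 1.7-fold higher number from compound 2 to compound 3 (0.24 log units; within the scatter); its furthest is compound 1 a 5.7-fold lower number from compound 1 to compound 3 (0.76 log units; beyond the scatter).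

Compound 4 `COCCO/C(O)=C1\C(C)=NC(C)=C([N+](=O)[O-])C1c1ccncc1` is not yet measured in this assay. It differs from compound 3 in one place: methoxymethyl in place of isopropyl on a saturated chain carbon bound to an oxygen on an unsaturated carbon

The measured steps that bear on this all vary the group on the oxygen on an unsaturated carbon. From the methyl of compound 1, cyclohexyl gave a 9.8-fold lower number from compound 1 to compound 2 (0.99 log units; beyond the scatter) and the addition of isopropyl gave a 5.7-fold lower number from compound 1 to compound 3 (0.76 log units; beyond the scatter); exchanging cyclohexyl for isobutyl gave a 1.7-fold higher number from compound 2 to compound 3 (0.24 log units; within the scatter). Across the three compounds the enlarged groups give lower numbers than compound 1, with no exception among them. Among the compounds with values here, no measured step tests the exchange of isopropyl for methoxymethyl itself, so the direction is uncertain; a modest step toward the number of compound 1 is expected, a 1.8-fold higher number from compound 3 to compound 4 (0.25 log units; within the scatter).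

Compound 4 is therefore estimated at 15000 nM in this assay, within a range of 6000 nM to 40000 nM.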

Compound 4, half-maximal effective concentration: 37700 nM
The estimate for compound 4 lay 2.5-fold (0.40 log units) below the measured number; the range from low to high includes it.
By their numbers in this assay, from the lowest: compounds 2 and 3 (each within the scatter of the next); then compounds 4 and 1 (each within the scatter of the next).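

In this assay, enlarging the group on the oxygen on an unsaturated carbon is not enough by itself to lower the number: the exchanged parts have the same count of heavy atoms, yet a 4.4-fold higher number from compound 3 to compound 4 (0.65 log units; beyond the scatter) follows when methoxymethyl replaces isopropyl. The 2-methoxyethyl group also falls short of cyclohexyl, with a 7.6-fold higher number from compound 2 to compound 4 (0.88 log units; beyond the scatter) for that exchange, and it goes against the earlier pattern of enlarged groups giving lower numbers than the methyl group, as a 1.3-fold lower number from compound 1 to compound 4 (0.11 log units; within the scatter) leaves compound 4 level with compound 1 within the scatter, while compound 2 and compound 3 remain the enlarged groups that give lower numbers. No measurement on hand accounts for the gap between the isobutyl and 2-methoxyethyl groups.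

The compounds shown do not separate the effect of the chain oxygen from that of its place along the chain, which a 3-methoxypropyl or an ethoxyethyl group would address. They also leave open how a 2-hydroxyethyl or 2-(dimethylamino)ethyl group would read at this position, and whether a longer plain alkyl chain would stay with isobutyl and cyclohexyl.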